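A few compounds are considered here, and "the series" means these few. Any claim that something is new, unique, unknown or untested is made for them only; others in the source may bear on it.

Compound 1 `CCOC(=O)C1=C(C)NC(C)=C(C(=O)OCC)C1c1ccc(OCC(=O)Nc2nc3ccccc3s2)cc1` in a functional assay on the whole organism (strain Wistar) for inhibition, with Rattus norvegicus as the target, read by paw edema, with stated times of 30 min and 1 h, at a dose of 20 mg/kg (a lower number here means less inhibition, a higher number more inhibition at the dose given (going by the name of the read-out)), gives 54.5%. Compound 2 `CCOC(=O)C1=C(C)NC(C)=C(C(=O)OCC)C1c1ccc(OCC(=O)NNC(=O)c2sccc2Cl)cc1` in this assay gives 39.7%, the lower of the two numbers, and the step of a number 14.8 percentage points lower from compound 1 to compound 2 (beyond the scatter) lies beyond the scatter. Compound 3 `CCOC(=O)C1=C(C)NC(C)=C(C(=O)OCC)C1c1ccc(OCC(=O)NNC(=O)c2ccsc2Cl)cc1` shares the core of compound 2 and differs from it only in the chlorothiophene group on the carbonyl carbon: 2-chlorothiophen-3-yl in place of 3-chlorothiophen-2-yl on a carbonyl carbon. Going by the values given here, the one measured step concerns a different part of the molecule, so nothing measured speaks for a shift in either direction, and the expected step of a number 0.3 percentage points higher from compound 2 to compound 3 (within the scatter) stays within the scatter. Compound 3 in this assay is therefore estimated at 40%, between 25% and 55%.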

Compound 3, a percentage reported as inhibition, in the whole organism at one dose (the size of the read-out at that dose, not a potency): 42.3%
The estimate for compound 3 lay 2.3 percentage points below the measured number; the range from low to high includes it.
By their numbers in this assay, from the lowest: compounds 2 and 3 (each within the scatter of the next); then compound 1.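

Exchanging 3-chlorothiophen-2-yl for 2-chlorothiophen-3-yl on the carbonyl carbon, with the same atoms joined differently, gives a number 2.6 percentage points higher from compound 2 to compound 3 (within the scatter) in this assay at this position. With a number 12.2 percentage points lower from compound 1 to compound 3 (beyond the scatter) as well, the lower reading against the 1,3-benzothiazol-2-yl compound holds for both chlorothiophene arrangements. No available evidence explains either step. Still open, on these data alone, is how a plain thiophene or a phenyl group on this carbonyl carbon would read. Also open, as far as these compounds go, is whether a methyl group in place of the chlorine would change the number.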